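Swapping Hydroxy for Ethylamino on a Saturated Chain Carbon

This account rests on a few compounds, and the source may have more. Where it says the series, first, only, none or still open, it means among the compounds named here.

Among the measured compounds shown here, in a functional assay on A2780 cells (Homo sapiens) for antiproliferative activity, read by MTT assay, with a stated time of 48 h (a lower number here means a stronger inhibitor, a higher number a weaker inhibitor), compound 1 (`COc1ccc(C(=O)c2ccc(OC)c3c2OC(C)(C)C=C3)c(NC(=O)CO)c1`) gives 100 nM, the lower of the two numbers measured so far. Compound 2 (`COc1ccc(C(=O)c2ccc3c(c2)C=CC(C)(C)O3)c(NC(=O)CN)c1`) gives 590 nM, a gap beyond the usual scatter. Compound 3 (`CCNCC(=O)Nc1cc(OC)ccc1C(=O)c1ccc(OC)c2c1OC(C)(C)C=C2`) departs from compound 1 in one place, with ethylamino in place of hydroxy on a saturated chain carbon bound to a carbonyl carbon. For the measured compounds named here, no measured step between compounds differing in one place is available, so any forecast remains loose. A moderate move toward a higher number in this assay is expected, and it may not clear the scatter. This expectation rests only on the higher reading of compound 2 at 590 nM. The expected change is a 2.8-fold higher number from compound 1 to compound 3 (0.45 log units; beyond the scatter). For compound 3, the estimated value is 280 nM, with an expected range of 70 nM to 1200 nM.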

Compound 3, half-maximal inhibitory concentration: 1980 nM
Compound 3: middle estimate off by 7.1-fold (0.85 log units), on the low side; measured number outside the range, above it.
By their numbers in this assay, from the lowest: compound 1; then compound 2; then compound 3.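

In this assay, among the compounds shown here, the replacement of hydroxy by ethylamino on a saturated chain carbon bound to a carbonyl carbon gives a 20-fold higher number from compound 1 to compound 3 (1.30 log units; beyond the scatter), the first direct reading of a change at this position, as the earlier compounds offered no pair differing in one place. The step is large and shows that this position is sensitive to the exchange, even though the hydrogen-bond donor and acceptor counts of the two groups are the same and only the heavy-atom count changes, from 1 to 3. Nothing available bears on why the number rises.

The compounds shown leave open whether the nitrogen or the two added carbons account for the step. Methylamino, dimethylamino or a longer chain ending in hydroxy, at this same place on the core of compound 1, could help separate the two.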